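Swapping an Aromatic Ring for an Ether on the Shared Core

A few compounds are considered here, and "the series" means these few. Any claim that something is new, unique, unknown or untested is made for them only; others in the source may bear on it.

Compound 1 `Cc1cc(C)c(CN2CCc3ccc(-c4c(C)noc4C)c(Cl)c3C2=O)c(=O)[nH]1` is built on a shared core, and in an assay on Sf9 cells for inhibition of histone-lysine N-methyltransferase EZH2 (Homo sapiens), read by scintillation counting, with a stated time of 60 min, in the presence of a further agent that is not named here (on this read-out higher numbers stand for weaker inhibition and lower numbers for stronger inhibition), compound 1 gives 3.2 nM, the lowest of the two numbers reported. Compound 2 `Cc1cc(C)c(CN2CCc3c(Cl)cc(-c4c(C)n[nH]c4C)c(Cl)c3C2=O)c(=O)[nH]1` carries a different arrangement on the same core and gives 16 nM in this assay, a gap from compound 1 that lies beyond the usual scatter. Compound 3 `COc1cccc(C(=O)NCc2c(C)cc(C)[nH]c2=O)c1` is a smaller, open-chain relative; in this assay compound 3 gives > 150000 nM, which is a limit of the assay rather than a number.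

Within the data shown here, compound 4 `Cc1cc(C)c(CN2CCc3ccc(O[C@@H]4CCOC4)c(Cl)c3C2=O)c(=O)[nH]1` is the step under consideration. (oxolan-3-yl)oxy in place of 3,5-dimethyl-1,2-oxazol-4-yl on an aromatic carbon No measured pair here shows the effect of such an exchange, so the expectation rests on compound 1 alone. The number is expected to rise, meaning weaker inhibition, by an amount beyond the scatter, and the estimated step of a 16-fold higher number from compound 1 to compound 4 (1.19 log units; beyond the scatter) reflects that. Compound 4 is estimated at 50 nM, within a range from 8 nM to 400 nM.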

Compound 4, half-maximal inhibitory concentration: 28 nM
The estimate for compound 4 lay 1.8-fold (0.25 log units) above the measured number, and the stated range covers the measured number.
By their numbers in this assay, from the lowest: compound 1; then compounds 2 and 4 (each within the scatter of the next). At a limit, above all of these: compound 3.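

In this assay, placing (oxolan-3-yl)oxy instead of 3,5-dimethyl-1,2-oxazol-4-yl on this aromatic carbon, ortho to a chloro group, gives an 8.8-fold higher number from compound 1 to compound 4 (0.94 log units; beyond the scatter), so this exchange costs inhibition by a real margin. Even so, compound 4 gives 28 nM, which shows that an aromatic ring at this position is not required for inhibition in the nanomolar range. Nothing in the information available explains why the number rises with this exchange.

The compounds shown leave open how the opposite arrangement at the defined stereocentre of the (oxolan-3-yl)oxy group would read in this assay. They also leave open how an amine or a carboxylic acid on the same aromatic carbon would compare with compound 1 and compound 4.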